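The source may hold more compounds than are shown below. What is called first, only, known or untested is meant among the compounds shown, and "the series" means these compounds.

The study compares analogues built on a shared core, all tested in a functional assay on RPMI8266 cells (Homo sapiens) for inhibition, read by sulforhodamine B assay, with a stated time of 48 h; a higher number here means a weaker inhibitor of growth, a lower number a stronger inhibitor of growth. Compound 1 `COc1cc(C)cc(-c2nn(CC#N)cc2-c2ccc(-c3cccc(C(C)=O)c3)nc2)c1` gives 3300 nM in this assay. Compound 2 `Cc1cc(O)cc(-c2nn(CC#N)cc2-c2ccnc(-c3ccc(Oc4ccccc4)cc3)c2)c1` gives 2250 nM in this assay. Going by the values given here, of the two numbers measured so far, that of compound 2 is the one nearer the low end, but the gap to compound 1 lies within the usual scatter of repeated measurements, so the two compounds cannot be told apart on this evidence.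

The next step leads from compound 2 to compound 3 `Cc1cc(O)cc(-c2nn(CC#N)cc2-c2ccnc(-c3ccc(N(C)C)cc3)c2)c1`. The change is a single one: dimethylamino in place of phenoxy on an aromatic carbon. Among the compounds with values here, no pair of measured compounds shows the effect of this exchange, so there is no measured step to lean on. In the absence of such a step, no change beyond the scatter is expected in this assay, in either direction. Compound 3 is therefore expected to give about 2500 nM in this assay, with a range from 800 nM to 8000 nM. That estimate amounts to an expected step of a 1.1-fold higher number from compound 2 to compound 3 (0.05 log units; within the scatter).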

Compound 3, concentration for 50% growth inhibition: 3710 nM
For compound 3 the middle estimate is 1.5-fold (0.17 log units) below the measured one, and the stated range covers the measured number.
By their numbers in this assay, from the lowest: compounds 2, 1 and 3 (each within the scatter of the next).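

In this assay, dimethylamino in place of phenoxy on the aromatic carbon para to a large group gives a 1.6-fold higher number from compound 2 to compound 3 (0.22 log units; within the scatter), so this first single-place exchange at this position does not separate the two compounds. The exchange removes a six-membered aromatic ring of carbon only and replaces a group of 7 heavy atoms with one of 3, while each group has 0 hydrogen-bond donors and 1 hydrogen-bond acceptor; even so, the step stays within the scatter, which shows that, in this one pair, this large a change in the group at this position leaves the read-out unresolved. No measurement at hand bears on this result or offers an explanation for it.

The compounds shown leave open whether a carboxylic acid or a morpholine at this position would stand beyond the scatter from compound 2, in either direction. Compound 1 differs from compound 2 and compound 3 in more than one place, so it cannot show whether this exchange would give a similar step on a different substitution pattern of the shared core.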